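The source may hold more compounds than are shown below. What is called first, only, known or untested is meant among the compounds shown, and "the series" means these compounds.

Three analogues share one core. Compound 1 `O=C(Nn1c(-c2ccccc2)nc2c(-c3ccc(Cl)cc3)n[nH]c2c1=O)c1ccccc1` gives 20100 nM in a functional assay on DU-145 cells (Homo sapiens) for inhibition, read by MTT assay, with a stated time of 2 days; on this read-out higher numbers stand for weaker inhibition of growth and lower numbers for stronger inhibition of growth; compound 2 `CCCc1nc2c(-c3ccc(Cl)cc3)n[nH]c2c(=O)n1NC(=O)c1ccccc1` gives 29200 nM; compound 3 `CCCCCc1nc2c(-c3ccc(Cl)cc3)n[nH]c2c(=O)n1NC(=O)c1ccccc1` gives 22100 nM. Compound 3 sits second highest of the three numbers, nearest to compound 1 and furthest from compound 2, both gaps within the scatter. The steps of a 1.5-fold higher number from compound 1 to compound 2 (0.16 log units; within the scatter), a 1.1-fold higher number from compound 1 to compound 3 (0.04 log units; within the scatter) and a 1.3-fold lower number from compound 2 to compound 3 (0.12 log units; within the scatter) all stay within the scatter, so alterations at this point of the core have shown no clear effect so far. Compound 4 `O=C(Nn1c(CCC2CCCC2)nc2c(-c3ccc(Cl)cc3)n[nH]c2c1=O)c1ccccc1` differs from compound 3 by cyclopentyl in place of propyl on a saturated chain carbon, two bonds along the chain from an aromatic carbon. Among the measured compounds shown here, the closest precedent is the chain lengthening from compound 2 to compound 3, itself within the scatter; on that basis no step beyond the scatter is expected in this assay. Compound 4 is therefore estimated at 22000 nM, with a range from 10000 nM to 48000 nM, an expected step of a 1.0-fold lower number from compound 3 to compound 4 (0.00 log units; within the scatter).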

Compound 4, concentration for 50% growth inhibition: 10200 nM
Beside the measured number, compound 4's estimate is 2.2-fold (0.33 log units) above it; the measured number falls inside the stated range.
By their numbers in this assay, from the lowest: compounds 4, 1, 3 and 2 (each within the scatter of the next, the first and the last beyond it).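

In this assay, among the compounds shown here, ending the chain in a cyclopentyl ring gives the first steps beyond the scatter at this position, both modest (a 2.2-fold lower number from compound 3 to compound 4 (0.34 log units; beyond the scatter); a 2.9-fold lower number from compound 2 to compound 4 (0.46 log units; beyond the scatter)), whereas the propyl, pentyl and phenyl groups did not separate. Against the phenyl group, the 2-cyclopentylethyl group stays within the scatter (a 2.0-fold lower number from compound 1 to compound 4 (0.29 log units; within the scatter)), so compound 4 is not set apart from every analogue. No measurement shown accounts for these steps.

As far as these compounds go, whether the lower number depends on the ring itself or only on chain size remains open. A longer chain such as heptyl, or a cyclohexyl or piperidine ring at the chain end, would test this.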